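The compounds below may be only part of what the source reports. "The series", "measured", "known", "first", "only" and "open" are said of these compounds alone.

Working notes on the series. In a functional assay on MDA-MB-436 cells (Homo sapiens) for antiproliferative activity, read by MTT assay, with a stated time of 24 h (a higher number here means a weaker inhibitor, a lower number a stronger inhibitor), compound 2 (`O=C(O)CC(NS(=O)(=O)c1ccccc1)c1ccc(Cl)cc1Cl`) gives 59000 nM, compound 1 (`O=C(O)CC(NS(=O)(=O)c1cc(F)cc(F)c1)c1ccccc1`) gives 69400 nM, and compound 3 (`O=C(O)CC(NS(=O)(=O)c1ccc(C(F)(F)F)cc1)c1ccc(Cl)cc1Cl`) gives 37600 nM. Compound 2 lies within the scatter of both of the others, so its value gives no firm place in an order.

The next compound is compound 4 (`O=C(O)CC(NS(=O)(=O)c1cc(F)cc(F)c1)c1ccc(Cl)cc1Cl`). Its change from compound 2 is 3,5-difluorophenyl in place of phenyl on a sulfonyl sulfur.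

Among the compounds with values here, no measured pair isolates this change. The closest evidence is a 1.6-fold lower number from compound 2 to compound 3 (0.20 log units; within the scatter), where trifluoromethyl replaces hydrogen on an aromatic carbon of the group on the sulfonyl sulfur. That step stays within the scatter. Compound 1 carries the same 3,5-difluorophenyl and stands at 69400 nM, but it differs from compound 4 elsewhere in the structure, so it offers only indirect support.

On this evidence, no step beyond the scatter is expected in this assay, and no firm direction can be assigned. The expected step is a 1.2-fold lower number from compound 2 to compound 4 (0.07 log units; within the scatter), which would remain within the scatter. For compound 4 the estimated value is 50000 nM, with an expected range from 26000 nM to 90000 nM.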

Compound 4, half-maximal inhibitory concentration: 49600 nM
Estimate against measurement, compound 4: 1.0-fold (0.00 log units) above, within the range that was stated.
By their numbers in this assay, from the lowest: compounds 3, 4, 2 and 1 (each within the scatter of the next).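

In this assay, within the data shown here, compound 4 provides the first measured pair that isolates 3,5-difluorophenyl in place of phenyl on a sulfonyl sulfur. The result is a 1.2-fold lower number from compound 2 to compound 4 (0.08 log units; within the scatter), so no effect of this change at this position can be resolved in this assay. Compound 4 also isolates 2,4-dichlorophenyl in place of phenyl on a saturated chain carbon bound to a saturated chain carbon and a sulfonamide nitrogen, giving a 1.4-fold lower number from compound 1 to compound 4 (0.15 log units; within the scatter), so with 3,5-difluorophenyl on the sulfonyl sulfur in both compounds, that change cannot be resolved either. No supporting measurement is available to account for either step.

The groups shown on the sulfonyl sulfur are limited to phenyl and its fluorine-bearing or trifluoromethyl-bearing forms, so it remains open whether a methoxy or amino substituent on that phenyl, or a longer alkyl chain in its place, would give a step beyond the scatter. As far as these compounds go, the carboxylic acid is common to all four compounds, so the effect of replacing it with a primary amide or a tetrazole also remains open.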